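The compounds below may be only part of what the source reports. "The series", "measured", "known", "first", "only" and "open" are said of these compounds alone.

Working notes on the series. The shared core is carried by compound 1 `CCCC(CCO)n1cnc2c(Cl)nc(F)nc21`, compound 2 `CCCC(CCO)n1cnc2c(Cl)ncnc21`, compound 3 `CCCCCCC[C@@H](CCO)n1cnc2c(Cl)ncnc21` and the not yet measured compound 4 `CCCCCCCCCC(CCO)n1cnc2c(Cl)ncnc21`. In a functional assay on HCT-116 cells (Homo sapiens) for antiproliferative activity, read by MTT assay, with a stated time of 48 h (a lower number here means a stronger inhibitor, a higher number a weaker inhibitor), compound 1 gives 16500 nM. In this assay compound 2 reaches only the assay limit of > 50000 nM, a limit and not a number; this is the limit of > 50000 nM in this assay, at which 1 of the 3 values shown sits. Going by the values given here, the one measured step, an at least 3.0-fold higher number from compound 1 to compound 2 (0.48 log units; beyond the scatter), thus runs from a number to a limit, so compound 2 stands at the weak end of what has been measured. Compound 3, with its heptyl chain, gives 10700 nM in this assay, a number within the range of the assay.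

The step from compound 2 to compound 4 is hexyl in place of hydrogen on a saturated chain carbon, four bonds along the chain from an aromatic nitrogen. Among the compounds with values here, no measured step covers this change; the measured step concerns the fluoro only. Compound 3 shows that a long chain on that carbon is compatible with a measurable number. Compound 4 is expected to sit near compound 3, estimated at 9000 nM (range 3000 nM to 30000 nM). That corresponds to an expected step of an at least 5.5-fold lower number from compound 2 to compound 4 (0.74 log units; beyond the scatter) from the limit of compound 2.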

Compound 4, half-maximal inhibitory concentration: 890 nM
The estimate for compound 4 lay 10-fold (1.00 log units) above the measured number; measured number below the stated range.
By their numbers in this assay, from the lowest: compound 4; then compounds 3 and 1 (each within the scatter of the next). At a limit, above all of these: compound 2.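

Hexyl in place of hydrogen on this saturated chain carbon gives an at least 56-fold lower number from compound 2 to compound 4 (1.74 log units; beyond the scatter), so in this assay this change does more than leave a measurable number: it produces a large shift towards lower numbers. The full size of that step cannot be read, as compound 2 stands at a limit and not a number: the limit of > 50000 nM in this assay, at which 1 of the 4 values shown sits. Compound 4 now holds the lowest number shown in the series, so this chain position, and not only the fluoro position, carries a change beyond the scatter.

Still open, going by these compounds, is whether a longer chain on this carbon, or a chain ending in an amine or a carboxylic acid, would lower the number further or raise it again. Also open, on these data alone, is whether the fluoro seen in compound 1 would add to the effect of the hexyl, and whether the two mirror-image forms at this carbon differ.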